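A few compounds are considered here, and "the series" means these few. Any claim that something is new, unique, unknown or untested is made for them only; others in the source may bear on it.

Measured in a functional assay on HeLa cells (Homo sapiens) for cytotoxicity, read by MTT assay, with a stated time of 72 h; a higher number here means a weaker inhibitor, a lower number a stronger inhibitor:
- compound 1 `O=C(/C=C/c1cccc(Cl)c1Cl)Nc1cc2c(Nc3ccc(F)c(Cl)c3)ncnc2cc1O[C@H]1CCOC1`: 30500 nM
- compound 2 `COc1cc(/C=C/C(=O)Nc2cc3c(Nc4ccc(F)c(Cl)c4)ncnc3cc2O[C@H]2CCOC2)cc(OC)c1OC`: 24500 nM
- compound 3 `COc1ccc(/C=C/C(=O)Nc2cc3c(Nc4ccc(F)c(Cl)c4)ncnc3cc2O[C@H]2CCOC2)c(OC)c1OC`: 4830 nM

These three compounds share a core and differ only in the aryl group on a double-bonded chain carbon bound to a double-bonded chain carbon. Compound 3 has the lowest number of the three, and both gaps to it lie beyond the scatter. The next compound, compound 4 `O=C(/C=C/c1ccc(F)cc1Cl)Nc1cc2c(Nc3ccc(F)c(Cl)c3)ncnc2cc1O[C@H]1CCOC1`, has not been measured. It carries 2-chloro-4-fluorophenyl in place of 2,3,4-trimethoxyphenyl on a double-bonded chain carbon bound to a double-bonded chain carbon.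

The closest measured guide is compound 1, which also bears a chlorinated phenyl group and gives 30500 nM. The change from it gives a 6.3-fold lower number from compound 1 to compound 3 (0.80 log units; beyond the scatter), a modest step. Compound 2 shows that methoxy groups alone do not guarantee a low number: a 1.2-fold lower number from compound 1 to compound 2 (0.10 log units; within the scatter). Only the 2,3,4-trimethoxyphenyl arrangement stands apart, with a 5.1-fold lower number from compound 2 to compound 3 (0.71 log units; beyond the scatter). Losing that group should therefore undo most of the advantage of compound 3, so a move to a higher number is expected, of similar size to these modest steps. The expected step is a 4.1-fold higher number from compound 3 to compound 4 (0.62 log units; beyond the scatter). Among the measured compounds shown here, no measured compound carries this exact chlorine and fluorine pattern, so the range is wide. For compound 4 the estimated value is 20000 nM, with an expected range from 7000 nM to 45000 nM.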

Compound 4, half-maximal inhibitory concentration: 37500 nM
Beside the measured number, compound 4's estimate is 1.9-fold (0.27 log units) below it, within the range that was stated.
By their numbers in this assay, from the lowest: compound 3; then compounds 2, 1 and 4 (each within the scatter of the next).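

Putting 2-chloro-4-fluorophenyl in place of 2,3,4-trimethoxyphenyl on the double-bonded chain carbon gives a 7.8-fold higher number from compound 3 to compound 4 (0.89 log units; beyond the scatter) in this assay, the first direct test of this swap, and the low number of compound 3 is not kept with this halogenated ring. The other two steps, a 1.5-fold higher number from compound 2 to compound 4 (0.18 log units; within the scatter) and a 1.2-fold higher number from compound 1 to compound 4 (0.09 log units; within the scatter), are both within the scatter, so three quite different aryl groups now give values that cannot be told apart, and compound 3 is the lone exception among the four. Nothing measured here explains why the 2,3,4-trimethoxyphenyl group stands apart from the rest.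

The compounds shown leave open whether all three methoxy groups of compound 3 are needed, or whether one or two in the same places on the ring would give a similarly low number. They also do not show how this position responds to a group of another kind, such as an amine or a carboxylic acid on the phenyl ring.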